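The compounds below may be only part of what the source reports. "The series", "measured", "known", "first", "only" and "open" are said of these compounds alone.

Measured so far:
- Compound 1 `CCOC(=O)c1cccc(-c2ccc(OCC)cc2)c1`: in an assay on COS-7 cells for inhibition of patatin-like phospholipase domain-containing protein 2 (Mus musculus) (on this read-out lower numbers stand for stronger inhibition and higher numbers for weaker inhibition), compound 1 gives 50000 nM
- Compound 2 `CCOC(=O)c1ccc(-c2ccc(OCC)cc2)[nH]1`: compound 2 gives only the limit > 200000 nM, at which this assay stops counting
- Compound 3 `CCNS(=O)(=O)c1cccc(-c2ccc(OCC)cc2)c1`: compound 3 gives 200000 nM

Among the numbers that are not limits, compound 3 stands highest: the step of a 4.0-fold higher number from compound 1 to compound 3 (0.60 log units; beyond the scatter) takes it beyond the scatter away from compound 1. One of the three values shown is a limit, (the limit of > 200000 nM in this assay, at which 1 of the 3 values shown sits), and compound 3 sits close to it.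

Compound 4 `CCOc1ccc(-c2cccc(S(=O)(=O)NC)c2)cc1` is not yet measured. From compound 3 it differs by one small change, (hydrogen in place of methyl on a saturated chain carbon bound to a sulfonamide nitrogen), that is, ethylsulfamoyl to methylsulfamoyl. None of the measured steps touches this part of the molecule; the only step shown swaps a whole group on the aromatic ring, so no measured evidence bears on shortening the chain on the sulfonamide nitrogen. The expectation is therefore no step beyond the scatter, with the number staying near where compound 3 stands, so close to the limit that the assay may again report only a limit. For compound 4 the estimate is 200000 nM, between 70000 nM and 600000 nM, which as a step from compound 3 is expected to be no change at the digits printed from compound 3 to compound 4 (within the scatter).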

Compound 4, half-maximal inhibitory concentration: 200000 nM
Beside the measured number, compound 4's estimate shows no gap at the digits printed; the range from low to high includes it.
By their numbers in this assay, from the lowest: compound 1; then compounds 3 and 4 (each within the scatter of the next).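

In this assay, shortening the chain on the sulfonamide nitrogen from ethylsulfamoyl to methylsulfamoyl gives no change at the digits printed from compound 3 to compound 4 (within the scatter), so this small change at this position does not separate the two sulfonamides. The gap to the ethoxycarbonyl compound also persists with the shorter chain, as a 4.0-fold higher number from compound 1 to compound 4 (0.60 log units; beyond the scatter), which means the weaker reading of compound 3 is not tied to its ethyl group alone. Compound 2 gives a limit, not a number, and the readings of both sulfonamides lie close to that limit: the limit of > 200000 nM in this assay, at which 1 of the 4 values shown sits.

The compounds shown leave open what a longer chain such as butyl, or a sulfonamide with no chain on its nitrogen, would give. They also leave open whether a carboxylic acid or an amide in place of the ethoxycarbonyl group would read lower than compound 1.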